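The compounds below may be only part of what the source reports. "The series", "measured", "known", "first", "only" and "open" are said of these compounds alone.

Three compounds of a shared core have been examined in an ADME assay on microsomes from liver (Homo sapiens) for metabolic stability; a higher number here means that the compound lasts longer, a lower number that the compound disappears faster. Compound 1 `O=C1NC(=O)/C(=C/C(c2ccc(-c3ccc4cccc(F)c4c3)[nH]c2=O)C2CC2)O1` carries a cyclopropyl, and in this assay compound 1 gives 1.98 h. Compound 2 `CC(C)C(c1ccc(-c2ccc3cccc(F)c3c2)[nH]c1=O)C1SC(=O)NC1=O` differs from compound 1 in both the ring group and the side chain, and in this assay compound 2 gives 1.87 h. The numbers of compound 1 and compound 2 lie within the scatter of each other, so neither can be called more stable than the other. Compound 3 `CC(C)C(/C=C1\NC(=O)NC1=O)c1ccc(-c2ccc3cccc(F)c3c2)[nH]c1=O` reaches the limit of this assay, and its reading of > 3 h is a limit rather than a number, as stated in the limit of > 3 h in this assay, at which 1 of the 3 values shown sits. For the measured compounds named here, the one measured step between neighbours, an at least 1.6-fold higher number from compound 2 to compound 3 (0.20 log units; that floor lies within the scatter), exchanges one five-membered ring for another on the side chain and does not touch the cyclopropyl.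

Compound 4 `O=C1NC(=O)/C(=C/C(c2ccc(-c3ccc4cccc(F)c4c3)[nH]c2=O)C2CCCC2)O1` is the compound not yet measured. Its change from compound 1 is cyclopentyl in place of cyclopropyl on a saturated chain carbon bound to an aromatic carbon and a double-bonded chain carbon. Going by the values given here, no measured step alters this group, so the measured steps give no direct guidance, and no step beyond the scatter is expected in this assay. Compound 4 is therefore expected to give about 2 h, with a range from 1 h to 4 h. The expected step is a 1.0-fold higher number from compound 1 to compound 4 (0.00 log units; within the scatter), which is an estimate and not a measurement.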

Compound 4, half-life: 1.21 h
Compound 4: middle estimate off by 1.7-fold (0.22 log units), on the high side, and the stated range covers the measured number.
By their numbers in this assay, from the lowest: compounds 4, 2 and 1 (each within the scatter of the next). At a limit, above all of these: compound 3.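

This is the first pair shown that differs only in the group on a saturated chain carbon bound to an aromatic carbon and a double-bonded chain carbon, so it gives the first direct reading of this position in this assay: cyclopentyl in place of cyclopropyl gives a 1.6-fold lower number from compound 1 to compound 4 (0.21 log units; within the scatter). A five-membered carbon ring can therefore stand in place of a three-membered one here with a difference that cannot be told apart from the usual spread of repeated measurements, although this rests on a single pair of compounds. Nothing among the results shown explains the size of this step.

As far as these compounds go, whether a group of another kind at this position, such as an amine, a carboxylic acid or a longer open chain, would give a step beyond the scatter remains open. For the compounds shown here, also open is whether the exchange of cyclopropyl for cyclopentyl would read the same way with the five-membered ring group of compound 3 in place of the one carried by compound 1 and compound 4.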